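Benzyl to 4-Methoxyphenyl on the Amine of a Shared Core

A few compounds are considered here, and "the series" means these few. Any claim that something is new, unique, unknown or untested is made for them only; others in the source may bear on it.

Of the compounds shown here, three on one core have numbers so far, and all of them sit at the weak end. Compound 1 `OCCCCNCc1nc2c(OCC3CCCCC3)cccc2[nH]1` carries a 4-hydroxybutyl chain on the amine nitrogen; in an assay on cells for inhibition of interleukin-5 receptor subunit alpha (Mus musculus), read by WST assay, with a stated time of 48 h, in the presence of a further agent that is not named here (a lower number here means a stronger inhibitor, a higher number a weaker inhibitor), compound 1 gives 30000 nM. Compound 2 `OCC(NCc1nc2c(OCC3CCCCC3)cccc2[nH]1)c1ccccc1` carries a 2-hydroxy-1-phenylethyl group there, and in this assay compound 2 gives 20000 nM, so the step of a 1.5-fold lower number from compound 1 to compound 2 (0.18 log units; within the scatter) does not separate the two. Compound 3 `c1ccc(CNCc2nc3c(OCC4CCCCC4)cccc3[nH]2)cc1` is the benzyl analogue. In this assay compound 3 reaches only the limit > 30000 nM, a limit and not a number, as the limit of > 30000 nM in this assay, at which 1 of the 3 values shown sits, records. The steps of a number no lower from compound 1 to compound 3 (the limit leaves the size open) and an at least 1.5-fold higher number from compound 2 to compound 3 (0.17 log units; that floor lies within the scatter) therefore place compound 3 no lower than its neighbours, without fixing how far above them it lies.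

Compound 4 `COc1ccc(NCc2nc3c(OCC4CCCCC4)cccc3[nH]2)cc1` differs from compound 3 by 4-methoxyphenyl in place of benzyl on an amine nitrogen. Going by the values given here, no measured pair exchanges a benzyl for an aryl group on that nitrogen, so no step bears on it directly; the nearest changes, those leading to compound 3, all end at a limit. The expected step of a number no higher from compound 3 to compound 4 (the limit leaves the size open) is therefore no more than a move within the scatter. Compound 4 is expected to give about 30000 nM in this assay, with an estimated range from 10000 nM to 100000 nM, and quite possibly only a limit again.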

Compound 4, half-maximal inhibitory concentration: > 30000 nM
Compound 4 was reported as a limit (the forecaster's own chance of this, stated with the estimate: 60%); the middle value lies on the limit itself.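

Set on the amine nitrogen, the 4-methoxyphenyl group brings an oxygen and a hydrogen-bond acceptor that the benzyl group lacks, yet in this assay compound 4 again gives only a limit, > 30000 nM, and the change is a step that the two limits leave unreadable from compound 3 to compound 4. Going by these compounds alone, the benzyl result was therefore not a lone case, and the limit now holds for a second aromatic group on this nitrogen: the limit of > 30000 nM in this assay, at which 2 of the 4 values shown sit. The only step that can be read is an at least 1.5-fold higher number from compound 2 to compound 4 (0.17 log units; that floor lies within the scatter), so it does not separate the two compounds, and neither the step just given for the benzyl group nor a number no lower from compound 1 to compound 4 (the limit leaves the size open) can be read.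

The compounds shown therefore leave open whether any group on this amine nitrogen can bring the number clearly below the limit, since the hydroxyalkyl chain, the 2-hydroxy-1-phenylethyl group, the benzyl group and the 4-methoxyphenyl group are not told apart by any readable step beyond the scatter. Going by these compounds, what a carboxylic acid or a second amine at the end of a chain on that nitrogen would give also remains open, as does how much the rest of the shared core contributes to the number.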